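The compounds below may be only part of what the source reports. "The series", "measured", "known", "first", "only" and "open" are said of these compounds alone.

In a functional assay on NCI-H226 cells (Homo sapiens) for inhibition, read by colorimetric assay and sulforhodamine B assay, with a stated time of 48 h; a higher number here means a weaker inhibitor of growth, a lower number a stronger inhibitor of growth:
- compound 1 `CCCCCCCCCCCC[C@@H](O)[C@H]1CC[C@H]([C@H](O)CCCCCCCCCCNC(=O)c2ccco2)O1`: 97700 nM
- compound 2 `CCCCCCCCCCCC[C@@H](O)[C@H]1CC[C@H]([C@H](O)CCCCCCCCCCNC(=O)c2cncs2)O1`: 100000 nM
- compound 3 `CCCCCCCCCCCC[C@@H](O)[C@H]1CC[C@H]([C@H](O)CCCCCCCCCCNC(=O)c2ccsc2)O1`: 2400 nM

Compound 2 stands at the weak end of these numbers. Its nearest neighbour gives a 1.0-fold higher number from compound 1 to compound 2 (0.01 log units; within the scatter), and its furthest gives a 42-fold lower number from compound 2 to compound 3 (1.62 log units; beyond the scatter).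

Compound 4 `CCCCCCCCCCCC[C@@H](O)[C@H]1CC[C@H]([C@H](O)CCCCCCCCCCNC(=O)c2ccnn2C)O1` has not yet been measured. It carries 1-methyl-1H-pyrazol-5-yl in place of 1,3-thiazol-5-yl on a carbonyl carbon.

The measured steps all swap the ring at this same place, but they point in different ways. One swap changes nothing beyond the scatter, as a 1.0-fold higher number from compound 1 to compound 2 (0.01 log units; within the scatter) shows, while another is large, as a 41-fold lower number from compound 1 to compound 3 (1.61 log units; beyond the scatter) shows. Ring swaps here can therefore leave the number where it is or shift it strongly, and no measured compound carries the entering ring. A modest move towards a lower number in this assay is expected, with much uncertainty, and no change beyond the scatter remains possible.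

The expected step is a 2.5-fold lower number from compound 2 to compound 4 (0.40 log units; beyond the scatter).

For compound 4 the estimated value is 40000 nM, with an expected range of 4000 nM to 110000 nM.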

Compound 4, concentration for 50% growth inhibition: 40700 nM
Compound 4: middle estimate off by 1.0-fold (0.01 log units), on the low side; measured number inside the range.
By their numbers in this assay, from the lowest: compound 3; then compound 4; then compounds 1 and 2 (each within the scatter of the next).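

In this assay, for the compounds shown here, the earlier compounds showed only two levels at this position on the carbonyl carbon, but the 1-methyl-1H-pyrazol-5-yl ring adds a level between them: the number falls modestly relative to the 1,3-thiazol-5-yl ring (a 2.5-fold lower number from compound 2 to compound 4 (0.39 log units; beyond the scatter)) and the furan-2-yl ring (a 2.4-fold lower number from compound 1 to compound 4 (0.38 log units; beyond the scatter)), yet it remains well short of the thiophen-3-yl ring (a 17-fold higher number from compound 3 to compound 4 (1.23 log units; beyond the scatter)). The 1,3-thiazol-5-yl and 1-methyl-1H-pyrazol-5-yl rings have the same counts of hetero atoms, hydrogen-bond donors and hydrogen-bond acceptors, so those counts alone do not fix the number in these two compounds. (No measurement shown accounts for these differences)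

From the compounds shown here alone, it remains open what the methyl contributes, which a 1H-pyrazol-5-yl ring without it could test. Going by these compounds, it is also open whether a thiophen-2-yl or phenyl ring would match or improve on compound 3 (2400 nM).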